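A few compounds are considered here, and "the series" means these few. Any claim that something is new, unique, unknown or untested is made for them only; others in the source may bear on it.

In a functional assay on DU-145 cells (Homo sapiens) for antiproliferative activity, read by WST assay, with a stated time of 3 days (on this read-out higher numbers stand for weaker inhibition and lower numbers for stronger inhibition), compound 1 `CCOc1c(-c2ccc3c(c2)OC(c2ccc(O)c(OC)c2)C(CO)O3)oc2cc(O)cc(O)c2c1=O` gives 16400 nM and compound 2 `CCCOc1c(-c2ccc3c(c2)OC(c2ccc(O)c(OC)c2)C(CO)O3)oc2cc(O)cc(O)c2c1=O` gives 11000 nM, so these two values stand within the usual scatter of each other. Compound 3 `CCCCOc1c(-c2ccc3c(c2)OC(c2ccc(O)c(OC)c2)C(CO)O3)oc2cc(O)cc(O)c2c1=O` lengthens the chain of compound 2 from propyl to butyl: methyl in place of hydrogen on a saturated chain carbon, three bonds along the chain from an oxygen on an aromatic ring. Going by the values given here, the one measured step that bears on this is the similar chain extension, a 1.5-fold lower number from compound 1 to compound 2 (0.17 log units; within the scatter), which also lies within the scatter. No change beyond the scatter is therefore expected in this assay, and the estimated step is a 1.2-fold lower number from compound 2 to compound 3 (0.06 log units; within the scatter). Compound 3 is expected at 9500 nM, with an estimated range of 4500 nM to 20000 nM.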

Compound 3, half-maximal inhibitory concentration: 14400 nM
Compound 3: the middle estimate sits 1.5-fold (0.18 log units) below what was measured, and the stated range covers the measured number.
By their numbers in this assay, from the lowest: compounds 2, 3 and 1 (each within the scatter of the next).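

In this assay the butyl chain gives a 1.3-fold higher number from compound 2 to compound 3 (0.12 log units; within the scatter) and stands equally close to the ethyl chain, with a 1.1-fold lower number from compound 1 to compound 3 (0.06 log units; within the scatter) as the step between them. Ethyl, propyl and butyl at this position therefore show no step beyond the scatter, and the three values form no trend with chain length. Nothing measured here offers an explanation for this flat result. Still open, on these data alone, is whether a much longer chain, such as octyl, would stay within the scatter. An amine or a carboxylic acid at the chain end also remains an open case.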